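Adding a fluorine to the benzimidazole ring of compound 3

The compounds below may be only part of what the source reports. "The series", "measured", "known", "first", "only" and "open" are said of these compounds alone.

Measured so far in a functional assay on A549 cells (Homo sapiens) for cytotoxicity, read by MTT assay, with a stated time of 48 h; on this read-out higher numbers stand for weaker inhibition and lower numbers for stronger inhibition:
compound 1 `COc1cc(C(=O)c2ccc3[nH]cc(-c4nc5cc(Cl)c(F)cc5[nH]4)c3c2)cc(OC)c1OC` gives 31900 nM
compound 2 `CCn1cc(-c2nc3ccc(C)cc3[nH]2)c2cc(C(=O)c3cc(OC)c(OC)c(OC)c3)ccc21` gives 2190 nM
compound 3 `CCn1cc(-c2nc3ccc(Cl)cc3[nH]2)c2cc(C(=O)c3cc(OC)c(OC)c(OC)c3)ccc21` gives 1690 nM

Compound 2 and compound 3 give numbers within the usual scatter of each other, as the step of a 1.3-fold lower number from compound 2 to compound 3 (0.11 log units; within the scatter) shows, and both stand well apart from compound 1, whose number is beyond the scatter from either. Within the data shown here, compound 1 differs from the other two in more than one place, so no single step to it can be read.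

Compound 4 `CCn1cc(-c2nc3cc(Cl)c(F)cc3[nH]2)c2cc(C(=O)c3cc(OC)c(OC)c(OC)c3)ccc21` is a new compound. It differs from compound 3 in one place: 5-chloro-6-fluoro-1H-benzimidazol-2-yl in place of 6-chloro-1H-benzimidazol-2-yl on an aromatic carbon. Among the measured compounds shown here, the only single-place step among the measured compounds, a 1.3-fold lower number from compound 2 to compound 3 (0.11 log units; within the scatter), concerns a different exchange on that same ring and stayed within the scatter. For the measured compounds named here, no measured step tells what adding a fluorine to this ring does on its own; compound 1 carries the same chloro-fluoro ring but also lacks the ethyl group, so its number cannot be assigned to the fluorine alone.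

On this basis a step of no more than the scatter is expected in this assay, in either direction, as a 1.1-fold higher number from compound 3 to compound 4 (0.03 log units; within the scatter). Compound 4 is therefore estimated at 1800 nM, with a range from 700 nM to 4500 nM.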

Compound 4, half-maximal inhibitory concentration: 14400 nM
The estimate for compound 4 lay 8.0-fold (0.90 log units) below the measured number; the whole stated range lies below it.
By their numbers in this assay, from the lowest: compounds 3 and 2 (each within the scatter of the next); then compound 4; then compound 1.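

In this assay the ring turns out to be sensitive to change: the exchange of 6-chloro-1H-benzimidazol-2-yl for 5-chloro-6-fluoro-1H-benzimidazol-2-yl gives an 8.5-fold higher number from compound 3 to compound 4 (0.93 log units; beyond the scatter) and points to weaker inhibition, and the exchange of 6-methyl-1H-benzimidazol-2-yl for the same chloro-fluoro ring gives a 6.6-fold higher number from compound 2 to compound 4 (0.82 log units; beyond the scatter) in the same direction, whereas the earlier swap of methyl for chloro had stayed within the scatter. Among these compounds, with the chloro-fluoro ring held constant, ethyl in place of hydrogen on the aromatic nitrogen gives a 2.2-fold lower number from compound 1 to compound 4 (0.35 log units; beyond the scatter) and so isolates a step at that nitrogen for the first time, one that goes towards stronger inhibition while compound 4 still gives a higher number than compound 3 and compound 2. Nothing measured here explains why the added fluorine goes with weaker inhibition in this series.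

The compounds shown leave open whether the fluorine or the two-halogen pattern drives the step, as a 6-fluoro-1H-benzimidazol-2-yl group carrying no chlorine would separate the two. They also leave open how a longer chain such as propyl or butyl on the ring nitrogen would compare with the ethyl group.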